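This account rests on a few compounds, and the source may have more. Where it says the series, first, only, none or still open, it means among the compounds named here.

Of the compounds shown here, two of a shared core have been measured in an assay on membranes from HeLa cells for displacement of a labelled ligand from adenosine receptor A3 (Homo sapiens), read by scintillation counting, with a stated time of 180 min, tested at 1 uM; on this read-out lower numbers stand for less inhibition and higher numbers for more inhibition at the one concentration tested (going by the name of the read-out). Compound 1 `CC1=C(C(=O)OCC(C)C)C(c2cccs2)NC(=O)N1` gives 11% in this assay. Compound 2 `CC1=C(C(=O)SC(C)C)C(c2ccco2)NC(=O)N1` gives 1% in this assay, the smaller of the two numbers, though the gap to compound 1 lies within the usual scatter, so the two cannot be ranked against each other. Within the data shown here, no step between measured compounds that differ in one place has been worked out.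

Compound 3 `CC1=C(C(=O)SC(C)C)C(c2cccs2)NC(=O)N1` is not yet measured. It differs from compound 2 in one place: thiophen-2-yl in place of furan-2-yl on a saturated ring carbon. Since the two measured numbers sit within the scatter of each other, no change beyond the scatter is expected; the step from compound 2 to compound 3 in this assay is estimated at a number 5 percentage points higher from compound 2 to compound 3 (within the scatter). Compound 3 is therefore expected to give about 6% in this assay, within a range from 0% to 20%.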

Compound 3, a percentage reported as inhibition, at one concentration (the size of the read-out at that concentration, not a potency): 1%
Estimate against measurement, compound 3: 5 percentage points above, and the stated range covers the measured number.
By their numbers in this assay, from the lowest: compounds 2, 3 and 1 (each within the scatter of the next).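

In this assay, thiophen-2-yl in place of furan-2-yl on the saturated ring carbon gives no change at the digits printed from compound 2 to compound 3 (within the scatter) and so, with the isopropylsulfanyl carbonyl held constant, the two rings cannot be told apart at this position. With thiophen-2-yl held constant, isopropylsulfanyl in place of isobutoxy on the carbonyl carbon gives a number 10 percentage points lower from compound 1 to compound 3 (within the scatter) and so neither single change moves the number beyond the scatter. No measured evidence bears on these results.

The compounds shown carry only these two five-membered aromatic rings at this position, so it remains open whether a phenyl ring or a ring bearing an amine would shift inhibition beyond the scatter. Also open, from the compounds shown here alone, is whether a longer chain on the carbonyl would do so.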